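Compound 3 to compound 4: a new group on the aromatic oxygen

The compounds below may be only part of what the source reports. "The series", "measured", "known", "first", "only" and "open" are said of these compounds alone.

In an ADME assay on L02 cells (Homo sapiens) for cytotoxicity, read by MTT assay (on this read-out lower numbers stand for stronger inhibition and higher numbers for weaker inhibition), compound 3 `COc1ccc(/C=C/C(=O)c2ccc(OC)c3c2OC(C)(C)C=C3)cc1OC(=O)CCl` reads > 10000 nM, which is a limit of the assay and not a number. Compound 1 `COc1ccc(/C=C/C(=O)c2ccc(OC)c3c2OC(C)(C)C=C3)cc1OCC=C(C)C` reads > 10000 nM, also a limit. Compound 2 `COc1ccc(/C=C/C(=O)c2ccc(OC)c3c2OC(C)(C)C=C3)cc1OCCCN(C)C` gives 8600 nM. The set therefore sits mostly at the limit of > 10000 nM in this assay, at which 2 of the 3 values shown sit.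

The next change leads to compound 4 `COc1ccc(/C=C/C(=O)c2ccc(OC)c3c2OC(C)(C)C=C3)cc1OS(=O)(=O)c1ccc(C)cc1`: (4-methylphenyl)sulfonyl in place of (chloromethyl)carbonyl on an oxygen on an aromatic ring. In words, (4-methylphenyl)sulfonyl stands in place of (chloromethyl)carbonyl on an oxygen on an aromatic ring.

Three measured steps changed the group on this same oxygen. They are an at least 1.1-fold lower number from compound 1 to compound 2 (0.06 log units; that floor lies within the scatter), an at least 1.1-fold higher number from compound 2 to compound 3 (0.06 log units; that floor lies within the scatter) and a step that the two limits leave unreadable from compound 1 to compound 3. For the measured compounds named here, none of them is readable as a step beyond the scatter, so they offer no precedent for a sizeable shift in this assay.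

The expected result is a step that the limit leaves unreadable from compound 3 to compound 4, with no direction expected beyond the scatter. A reading at the limit is the likeliest outcome. For compound 4 the estimated value is 12000 nM, with an expected range from 6000 nM to 30000 nM.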

Compound 4, half-maximal inhibitory concentration: > 10000 nM
Compound 4: a limit, no number; the forecaster's own chance of this, stated with the estimate: 70%; the middle value does not contradict the limit.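

In this assay compound 4 gives > 10000 nM, a limit of the assay and not a number. A group carrying a six-membered aromatic ring, (4-methylphenyl)sulfonyl, now joins the groups on this oxygen, and the reading stays where most of the set already lies: the limit of > 10000 nM in this assay, at which 3 of the 4 values shown sit. For the compounds shown here, the one step that can be read is an at least 1.1-fold higher number from compound 2 to compound 4 (0.06 log units; that floor lies within the scatter), so even this larger group gives no shift beyond the scatter, while the steps from compound 1 and from compound 3 to compound 4 cannot be read.

On these data alone, the actual values of compound 1, compound 3 and compound 4 remain unknown, so any order among them stays open. Also open, as far as these compounds go, is whether a different group on this oxygen, such as a carboxylic acid or a longer chain ending in an amine, would move the reading beyond the scatter.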